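A sulfonyl group on the ring amine of compound 2

The source may report more compounds than this note shows. Statements on the series, on what has been measured and on what is new or still open speak of the compounds shown alone.

Results so far in a functional assay on HepG2 cells (Homo sapiens) for cytotoxicity, read by MTT assay, with a stated time of 24 h; a higher number here means a weaker inhibitor, a lower number a stronger inhibitor:
Compound 1 (`O=C1/C(=C/c2cccnc2)CNC/C1=C\c1ccccc1F`): 21000 nM
Compound 2 (`O=C1/C(=C/c2ccncc2)CNC/C1=C\c1ccccc1F`): 8200 nM

Within the data shown here, of these two, compound 2 has the lower number, which marks it as the stronger inhibitor in this assay so far. Compound 3 (`O=C1/C(=C/c2ccncc2)CN(S(=O)(=O)c2ccc(Br)cc2)C/C1=C\c1ccccc1F`) differs from compound 2 at one place: (4-bromophenyl)sulfonyl in place of hydrogen on an amine nitrogen in a ring that is, (4-bromophenyl)sulfonyl in place of hydrogen on an amine nitrogen in a ring. Among the measured compounds shown here, the one measured step is modest, a 2.6-fold lower number from compound 1 to compound 2 (0.41 log units; beyond the scatter) and it swaps pyridin-3-yl for pyridin-4-yl, so it offers only a rough scale for a change on that nitrogen. For the measured compounds named here, no measured compound carries a group there. Given how much this change adds, a larger step towards a lower number is expected in this assay with wide uncertainty. The estimated step is a 2.7-fold lower number from compound 2 to compound 3 (0.44 log units; beyond the scatter) overall. For compound 3 the expected value is 3000 nM with an estimated range of 800 nM to 10000 nM overall.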

Compound 3, half-maximal inhibitory concentration: 9300 nM
The estimate for compound 3 lay 3.1-fold (0.49 log units) below the measured number; the measured number falls inside the stated range.
By their numbers in this assay, from the lowest: compounds 2 and 3 (each within the scatter of the next); then compound 1.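

In this assay, putting (4-bromophenyl)sulfonyl in place of hydrogen on the amine nitrogen in the ring gives a 1.1-fold higher number from compound 2 to compound 3 (0.05 log units; within the scatter) and leaves compound 2 and compound 3 indistinguishable. Compound 1 and compound 2 both carry only hydrogen on this nitrogen, so their step spoke only to the swap of pyridin-3-yl for pyridin-4-yl; now a large group on the nitrogen is seen to leave the number in the same range. No supporting measurement is available to explain this result.

One group says little about others at this nitrogen, such as a small methyl, an acetyl amide or a sulfonyl whose phenyl ring carries a carboxylic acid instead of bromine. As far as these compounds go, it also remains open whether the same sulfonyl would behave alike on compound 1.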